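From oxan-4-yl to 2-(oxan-4-yl)ethyl

The source may report more compounds than this note shows. Statements on the series, on what has been measured and on what is new or still open speak of the compounds shown alone.

In an ADME assay on S9 fraction from liver (Homo sapiens) for metabolic stability, with a stated time of 1 h (on this read-out lower numbers stand for a less stable compound and higher numbers for a more stable compound), compound 3 (`N#Cc1cnc(NCc2cnccc2C(F)(F)F)cc1NC1CCOCC1`) stands highest of the three measured compounds at 91% so far. Compound 2 (`N#Cc1cnc(NCc2cnccc2C(F)(F)F)cc1NC[C@H]1CC[C@@H](O)CC1`) gives 41% and compound 1 (`CO[C@H]1CC[C@@H](Nc2cc(NCc3cnccc3C(F)(F)F)ncc2C#N)CC1`) gives 19% by comparison. Compound 4 (`N#Cc1cnc(NCc2cnccc2C(F)(F)F)cc1NCCC1CCOCC1`) carries 2-(oxan-4-yl)ethyl in place of oxan-4-yl on a nitrogen on an aromatic ring. Within the data shown here, no measured step changes the chain length alone. The closest steps are large: a number 50 percentage points higher from compound 2 to compound 3 (beyond the scatter) and a number 72 percentage points higher from compound 1 to compound 3 (beyond the scatter) both end at oxan-4-yl. Only compound 2 has a chain on that nitrogen, and its value of 41% suggests a lower number. The expected change is a number 33 percentage points lower from compound 3 to compound 4 (beyond the scatter) as an estimate, a large step downward. Compound 4 is expected at 58% (range 30% to 82%).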

Compound 4, percent of the compound remaining: 23%
The estimate for compound 4 lay 35 percentage points above the measured number; the measured number lies below the stated range.
By their numbers in this assay, from the lowest: compounds 1 and 4 (each within the scatter of the next); then compound 2; then compound 3.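

In this assay, among these compounds, extending oxan-4-yl to 2-(oxan-4-yl)ethyl on the nitrogen while keeping the ring gives a number 68 percentage points lower from compound 3 to compound 4 (beyond the scatter), so chain length alone matters at this position, which no earlier step could isolate. The remaining steps are a number 18 percentage points lower from compound 2 to compound 4 (beyond the scatter) and a number 4 percentage points higher from compound 1 to compound 4 (within the scatter), leaving compound 4 unseparated from compound 1 despite their different substituents. No measurement at hand accounts for the drop. Open, going by these compounds, is whether the shorter (oxan-4-yl)methyl chain stays with compound 3 or compound 4.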